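The compounds below may be only part of what the source reports. "The series", "measured", "known", "first", "only" and "open" are said of these compounds alone.

Measured compounds in an ADME assay on HepG2 cells (Homo sapiens) for inhibition, with a stated time of 48 h; a lower number here means that less compound is needed, a higher number that more compound is needed for the effect:

compound 1 `C[C@H](C(=O)N1CCCCC1)N1CCN(S(=O)(=O)c2ccc(C(C)(C)C)cc2)CC1`: > 40000 nM (a limit)
compound 2 `CC(C(=O)N1CCC(C)(C)CC1)N1CCN(S(=O)(=O)c2ccc(C(C)(C)C)cc2)CC1`: > 40000 nM (a limit)
compound 3 `CC(C(=O)N1CCOCC1)N1CCN(S(=O)(=O)c2ccc(C(C)(C)C)cc2)CC1`: > 40000 nM (a limit)

In this assay compound 1 returns only a limit, > 40000 nM. Compound 2 likewise returns a limit, > 40000 nM. Compound 3 too returns a limit, > 40000 nM, so compound 3 stands where the other two stand, with no number of its own. Within the data shown here, the one measured step between neighbours, a step that the two limits leave unreadable from compound 2 to compound 3, cannot be read because of the limit of > 40000 nM in this assay, at which 3 of the 3 values shown sit.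

Compound 4 `CC(C(=O)N1CCc2ccccc2C1C)N1CCN(S(=O)(=O)c2ccc(C(C)(C)C)cc2)CC1` differs from compound 3 by 1-methyl-1,2,3,4-tetrahydroisoquinolin-2-yl in place of morpholin-4-yl on a carbonyl carbon. Among the measured compounds shown here, no measured step touches this change; the only comparison available is the unreadable one, and the three limits give no direction to build on. For the measured compounds named here, the account therefore rests on the observation that every value so far sits at the limit, and compound 4 is expected to sit there as well, the estimated step being a number no higher from compound 3 to compound 4 (the limit leaves the size open). For compound 4 the estimate is 40000 nM, with a range from 10000 nM to 120000 nM, and a high chance that this assay again reports only a limit.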

Compound 4, half-maximal effective concentration: 28000 nM
For compound 4 the middle estimate is 1.4-fold (0.15 log units) above the measured one, and the stated range covers the measured number.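

In this assay, compound 4 is the only one so far to return a number rather than a limit, so the group on the carbonyl carbon can bring the read-out inside the measured range. Placing 1-methyl-1,2,3,4-tetrahydroisoquinolin-2-yl in place of morpholin-4-yl gives an at least 1.4-fold lower number from compound 3 to compound 4 (0.15 log units; that floor lies within the scatter), and placing it in place of 4,4-dimethylpiperidin-1-yl gives an at least 1.4-fold lower number from compound 2 to compound 4 (0.15 log units; that floor lies within the scatter); both are floors only, so the true size of the change stays unknown. The step among the earlier compounds still cannot be read, because those compounds rest on one shared value: the limit of > 40000 nM in this assay, at which 3 of the 4 values shown sit.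

The compounds shown do not separate the contribution of the methyl group from that of the aromatic ring in the new group. As far as these compounds go, it remains open how the plain 1,2,3,4-tetrahydroisoquinolin-2-yl, without the methyl group, or an open-chain N-methylbenzylamine amide would read in this assay.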